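Second fluoro on the aryl group of compound 2

The compounds below may be only part of what the source reports. "The series", "measured", "known", "first", "only" and "open" are said of these compounds alone.

Two compounds of the shared core have numbers in an assay on Sf9 cells for inhibition of serine/threonine-protein kinase 4 (Homo sapiens), read by luminescence and ADP-Glo, with a stated time of 1 h, in the presence of a further agent that is not named here; on this read-out higher numbers stand for weaker inhibition and lower numbers for stronger inhibition. Compound 1 `CC(C)C1C(=O)N(C)c2cnc(Nc3ccc(S(N)(=O)=O)cc3)nc2N1C` gives 254 nM. Compound 2 `CN1C(=O)C(c2ccccc2F)N(C)c2nc(Nc3ccc(S(N)(=O)=O)cc3)ncc21` gives 75 nM, the lowest of the two numbers, and the step of a 3.4-fold lower number from compound 1 to compound 2 (0.53 log units; beyond the scatter) sets it beyond the scatter from compound 1. Compound 3 `CN1C(=O)C(c2c(F)cccc2F)N(C)c2nc(Nc3ccc(S(N)(=O)=O)cc3)ncc21` has no number yet. The change from compound 2 to compound 3 is fluoro in place of hydrogen on an aromatic carbon. For the measured compounds named here, the only measured step concerns the exchange of the whole group on the saturated ring carbon, so it bears on this change only loosely, and no step between two differently substituted aryl groups is known. A small step, if any, is therefore expected, possibly a slightly lower number. For compound 3 the estimate is 60 nM, with a range of 25 nM to 150 nM. This corresponds to an expected step of a 1.3-fold lower number from compound 2 to compound 3 (0.10 log units; within the scatter).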

Compound 3, half-maximal inhibitory concentration: 42 nM
The estimate for compound 3 lay 1.4-fold (0.15 log units) above the measured number; the measured number falls inside the stated range.
By their numbers in this assay, from the lowest: compounds 3 and 2 (each within the scatter of the next); then compound 1.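

In this assay the second fluoro, which turns 2-fluorophenyl into 2,6-difluorophenyl, stays within the scatter (a 1.8-fold lower number from compound 2 to compound 3 (0.25 log units; within the scatter)), so this aromatic carbon ortho to a large group accepts fluoro in place of hydrogen without a step that can be read as real. The gap to the isopropyl compound holds with the 2,6-difluorophenyl group as well (a 6.0-fold lower number from compound 1 to compound 3 (0.78 log units; beyond the scatter)), and this step lies beyond the scatter, as the one with 2-fluorophenyl does. No measurement at hand bears on the reason for these numbers.

Still open, as far as these compounds go, is what a plain phenyl, 2-chlorophenyl or 2-methoxyphenyl group would give on the saturated ring carbon, so any part played by fluoro itself cannot be separated from that of the aryl ring. Also open, from the compounds shown here alone, is how an amine or a carboxylic acid on that aryl ring would read.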